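Terminal hydroxy removal on the chain of compound 2

This account rests on a few compounds, and the source may have more. Where it says the series, first, only, none or still open, it means among the compounds named here.

Measured so far:
compound 1, `O=C(O)CCCCCOc1ccc2c(=O)cc(-c3ccc(O)cc3)oc2c1`, 3500 nM
compound 2, `O=c1c(-c2ccc(O)cc2)coc2cc(OCCCCCCO)ccc12`, 120 nM

In an assay (Cricetulus griseus) for inhibition of aldehyde dehydrogenase, mitochondrial (Homo sapiens) (on this read-out lower numbers stand for stronger inhibition and higher numbers for weaker inhibition), compound 2 gives the lowest of the two numbers recorded; the nearest, compound 1, is well beyond the scatter from it. For the measured compounds named here, the two compounds differ in more than one place, so what their values show is only that compound 2 is the stronger inhibitor.

Compound 3, `CCCCCCOc1ccc2c(=O)c(-c3ccc(O)cc3)coc2c1`, is the next step from compound 2. The change is hydrogen in place of hydroxy on a saturated chain carbon, six bonds along the chain from an oxygen on an aromatic ring. Going by the values given here, no measured pair shows this change in isolation, and compound 1 offers no guide, since its chain ends differently and its core is arranged differently.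

Among the compounds with values here, with no comparable step on record, a small shift, not clearly beyond the scatter, is expected from compound 2 to compound 3, namely a 1.7-fold higher number from compound 2 to compound 3 (0.22 log units; within the scatter). Compound 3 is therefore estimated at 200 nM, within 50 nM to 900 nM.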

Compound 3, half-maximal inhibitory concentration: 1500 nM
Compound 3: middle estimate off by 7.5-fold (0.88 log units), on the low side; measured number above the stated range.
By their numbers in this assay, from the lowest: compound 2; then compound 3; then compound 1.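

In this assay, for the compounds shown here, hydrogen in place of hydroxy on a saturated chain carbon, six bonds along the chain from an oxygen on an aromatic ring, gives a 13-fold higher number from compound 2 to compound 3 (1.10 log units; beyond the scatter) and is the first step that can be read in isolation. The hydroxy at this place therefore matters for the number in this assay, and the inhibition recorded for compound 2 is not retained by the plain chain of compound 3. No measurement on record gives a reason for the size of this step.

From the compounds shown here alone, whether the hydroxy itself is needed remains open, since an amine, an amide or a methyl ether at the same place would test other replacements. A longer or shorter chain carrying the hydroxy would show whether its distance from the aromatic oxygen also matters.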